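The compounds below may be only part of what the source reports. "The series", "measured", "known", "first", "only" and "open" are said of these compounds alone.

In this series the shared core of compound 1, `Cc1ccc2nc(-c3cccc(NC(=O)CCc4ccccc4)c3)[nH]c2c1`, carries a methyl group on its fused ring system. In an assay on cells for inhibition of matrix metalloproteinase-9 (Homo sapiens), read by fluorescence, with stated times of 15 min and 4 h (on this read-out higher numbers stand for weaker inhibition and lower numbers for stronger inhibition), compound 1 gives 26600 nM. Compound 2, `O=C(CCc1ccccc1)Nc1cccc(-c2nc3ccc(Br)cc3[nH]2)c1`, keeps everything else and differs only in that a bromo stands where the methyl stood: bromo in place of methyl on an aromatic carbon. In this assay compound 2 gives 14500 nM, and the step of a 1.8-fold lower number from compound 1 to compound 2 (0.26 log units; within the scatter) is one the assay cannot tell apart from a repeat of the same compound.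

Compound 3, `Cc1ccc2nc(-c3ccc(NC(=O)CCc4ccccc4)cc3)[nH]c2c1`, is built from the same atoms as compound 1 but joined differently; how the two cores differ is not broken down here. In this assay compound 3 gives 60000 nM, which leaves it beyond the scatter from compound 1 and still further from compound 2.

Compound 4, `O=C(CCc1ccccc1)Nc1ccc(-c2nc3ccc(Br)cc3[nH]2)cc1`, has not yet been measured. It stands to compound 3 as compound 2 stands to compound 1: bromo in place of methyl on an aromatic carbon. The place of the change is described in the same words for both pairs, so this is the same change applied to the other core. Going by the values given here, since the only measured instance of it, from compound 1 to compound 2, stayed within the scatter, the step from compound 3 to compound 4 is expected to be small as well, about a 1.7-fold lower number from compound 3 to compound 4 (0.23 log units; within the scatter). On that basis compound 4 is estimated at 35000 nM in this assay, with a plausible range from 15000 nM to 80000 nM.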

Compound 4, half-maximal inhibitory concentration: 11500 nM
Compound 4: middle estimate off by 3.0-fold (0.48 log units), on the high side; measured number below the stated range.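

In this assay, bromo in place of methyl on an aromatic carbon gives a 5.2-fold lower number from compound 3 to compound 4 (0.72 log units; beyond the scatter), a step that can be read as a real change, though a modest one. Set beside the earlier instance, the same exchange does not carry over at the same size from one core to the other: the same change on two cores in this assay, a 1.8-fold lower number (0.26 log units; within the scatter) from compound 1 to compound 2 and a 5.2-fold lower number (0.72 log units; beyond the scatter) from compound 3 to compound 4, 2.8-fold (0.45 log units) apart, beyond the scatter of two such steps. Both steps run towards a lower number, but the earlier one cannot be told apart from a repeat measurement, and two pairs neither give a rule for any further core nor show what sets the two steps apart.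

The compounds shown leave open whether other groups at this place, such as chloro, an amine or a carboxylic acid, would also give steps that differ between the two cores. They also leave open whether the difference between the steps would persist with a shorter or longer chain in place of the one that links the amide to the phenyl ring.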